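Two Fluorines on the Ring Phenyl: Unbound Fraction Expected

This account rests on a few compounds, and the source may have more. Where it says the series, first, only, none or still open, it means among the compounds named here.

Compound 2 `C[C@@H]1CN(c2cccc(F)c2)C(=O)c2cc(COc3ccc(F)cn3)nn21` was tested in an ADME assay on a cell-free system (plasma, Rattus norvegicus) for protein binding (a lower number here means a smaller unbound share, a higher number a larger unbound share of the compound), and gave 0.094. Within the data shown here, of the two measured compounds it shows the higher number, but its only neighbour, compound 1 `C[C@@H]1CN(c2ccc(F)cc2)C(=O)c2cc(COc3ccc(F)cc3)nn21`, stands within the scatter: in this assay compound 1 gives 0.06, so the two values cannot be ordered with confidence. Compound 3 `C[C@@H]1CN(c2c(F)cccc2F)C(=O)c2cc(COc3ccc(F)cn3)nn21` has not yet been measured. It differs from compound 2 in one place: 2,6-difluorophenyl in place of 3-fluorophenyl on an amide-type nitrogen in a ring. Among the measured compounds shown here, no measured pair shows this kind of change, so nothing in the data says how one more fluorine on this phenyl moves the unbound fraction. The expectation is therefore a step of a 1.3-fold lower number from compound 2 to compound 3 (0.13 log units; within the scatter) that stays within the scatter, possibly leaning towards a smaller unbound share. Because compound 1 gives 0.06 and compound 2 gives 0.094, both values frame the expectation. Compound 3 is estimated at 0.07 in this assay, with a range from 0.035 to 0.14.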

Compound 3, unbound fraction: 0.064
Compound 3: the middle estimate sits 1.1-fold (0.04 log units) above what was measured, and the stated range covers the measured number.
By their numbers in this assay, from the lowest: compounds 1, 3 and 2 (each within the scatter of the next).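

Among these compounds, the swap of 3-fluorophenyl for 2,6-difluorophenyl on the amide-type nitrogen in a ring gives the first step that can be read at this position: in this assay there is a 1.5-fold lower number from compound 2 to compound 3 (0.17 log units; within the scatter). The two compounds therefore cannot be told apart, and in this one pair, a second fluorine on this phenyl leaves no effect on the unbound fraction that stands clear of the scatter. Nothing measured here offers an explanation for this result.

From the compounds shown here alone, only fluorinated phenyl groups appear at this position, so it remains open how far the reading can be moved there. A phenyl carrying an amine or a carboxylic acid in place of fluorine, for example, might or might not shift the unbound fraction beyond the scatter.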